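Exchanging one fused bicyclic amine for another

The compounds below may be only part of what the source reports. "The series", "measured", "known", "first", "only" and "open" are said of these compounds alone.

Of the compounds shown here, three built on one shared core have been tested in a functional assay on K562 cells (Homo sapiens) for inhibition, read by trypan blue exclusion, with a stated time of 72 h; a lower number here means a stronger inhibitor, a higher number a weaker inhibitor. Compound 1 `Cn1c(=O)c(S(=O)(=O)c2ccc(F)cc2)cc2cnc(Nc3cccc4[nH]ccc34)nc21` gives 750 nM. Compound 2 `Cn1c(=O)c(S(=O)(=O)c2ccc(F)cc2)cc2cnc(Nc3cnc4[nH]ccc4c3)nc21` gives 750 nM. Compound 3 `Cn1c(=O)c(C(=O)Nc2ccc(F)cc2)cc2cnc(Nc3ccc4[nH]ccc4c3)nc21`, which differs from the other two in several places, gives 5000 nM. The step of no change at the digits printed from compound 1 to compound 2 (within the scatter) lies within the scatter, so compound 2 stands level with compound 1, the pair together at the lowest numbers seen, while compound 3 sits clearly higher, beyond the scatter.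

Compound 4 `Cn1c(=O)c(S(=O)(=O)c2ccc(F)cc2)cc2cnc(Nc3ccc4[nH]ncc4c3)nc21` differs from compound 2 by a group of 9 heavy atoms (7 carbon, 2 nitrogen; one five-membered aromatic ring with 2 hetero atoms, one six-membered aromatic ring of carbon only) in place of a group of 9 heavy atoms (7 carbon, 2 nitrogen; one five-membered aromatic ring with 1 hetero atom, one six-membered aromatic ring with 1 hetero atom), on a nitrogen on an aromatic ring. The group that enters is 1H-indazol-5-yl, placed on a nitrogen on an aromatic ring whose other neighbours are aromatic carbon.

For the measured compounds named here, only one measured step speaks to this kind of change: no change at the digits printed from compound 1 to compound 2 (within the scatter), where one fused bicyclic group replaced another at the same nitrogen and the number stayed within the scatter. On that evidence alone, no step beyond the scatter is expected in this assay, in either direction. Compound 4 is therefore estimated to give 800 nM, with an expected range from 350 nM to 1800 nM. The expected step is a 1.1-fold higher number from compound 2 to compound 4 (0.03 log units; within the scatter).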

Compound 4, half-maximal inhibitory concentration: 10000 nM
For compound 4 the middle estimate is 13-fold (1.10 log units) below the measured one; measured number outside the range, above it.
By their numbers in this assay, from the lowest: compounds 1 and 2 (each within the scatter of the next); then compounds 3 and 4 (each within the scatter of the next).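

Exchanging one fused bicyclic group for another on this nitrogen is not always a neutral change: in this assay, putting 1H-indazol-5-yl in place of the earlier group gives a 13-fold higher number from compound 2 to compound 4 (1.12 log units; beyond the scatter) and, against the other group, a 13-fold higher number from compound 1 to compound 4 (1.12 log units; beyond the scatter). The earlier pair had shown only no change at the digits printed from compound 1 to compound 2 (within the scatter), so similarity in overall shape and size does not guarantee a similar number at this position. The groups exchanged between compound 2 and compound 4 also match in heavy atoms, hydrogen-bond donors, hydrogen-bond acceptors and net charge, so these counts do not separate the two results, and no measurement here explains the large step.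

On these data alone, it remains open whether the step follows the second nitrogen in the five-membered ring, the carbon-only six-membered ring, the point of attachment, or some combination of these. A 1H-indazol-4-yl group on the core of compound 1 would keep the attachment of the 1H-indol-4-yl group while altering the ring atoms, and a 1H-benzimidazol-5-yl group would show whether moving that nitrogen within the five-membered ring matters.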